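Formyl Replaces the Arylsulfonyl Group on the Ring Nitrogen

The source may hold more compounds than are shown below. What is called first, only, known or untested is meant among the compounds shown, and "the series" means these compounds.

Compound 2 `Cc1ccc(S(=O)(=O)N2c3c(N)nc(N)nc3CCC2CN(C)c2ccc(C(=O)N[C@@H](CCC(=O)O)C(=O)O)cc2)cc1` stands highest of the two numbers in an assay on isolated protein for inhibition of Dihydrofolate reductase (Homo sapiens), read by spectrophotometry (a higher number here means a weaker inhibitor, a lower number a stronger inhibitor), where compound 2 gives 1070 nM. Among the measured compounds shown here, compound 1 `C=CCN1c2c(N)nc(N)nc2CCC1CN(C)c1ccc(C(=O)N[C@@H](CCC(=O)O)C(=O)O)cc1` gives 420 nM in this assay, and the step of a 2.5-fold higher number from compound 1 to compound 2 (0.41 log units; beyond the scatter) is the only measured change at this nitrogen. Compound 3 `CN(CC1CCc2nc(N)nc(N)c2N1C=O)c1ccc(C(=O)N[C@@H](CCC(=O)O)C(=O)O)cc1` differs from compound 2 by formyl in place of (4-methylphenyl)sulfonyl on a nitrogen on an aromatic ring in a ring. For the measured compounds named here, only that one step bears on the change, and it was modest, so compound 3 is expected to move back toward a lower number by a modest amount. Compound 3 is therefore estimated at 500 nM, with a range from 200 nM to 1500 nM. Compound 3 is expected to show a step of a 2.1-fold lower number from compound 2 to compound 3 (0.33 log units; beyond the scatter).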

Compound 3, half-maximal inhibitory concentration: 32 nM
For compound 3 the middle estimate is 16-fold (1.19 log units) above the measured one, and the stated range ends above it.
By their numbers in this assay, from the lowest: compound 3; then compound 1; then compound 2.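

In this assay this nitrogen proves far more sensitive to its substituent than the modest step between allyl and (4-methylphenyl)sulfonyl had shown: formyl brings a 33-fold lower number from compound 2 to compound 3 (1.52 log units; beyond the scatter) and also a 13-fold lower number from compound 1 to compound 3 (1.12 log units; beyond the scatter). Compound 3 therefore has the lowest number of the three, with its steps to both others beyond the scatter. Nothing available here accounts for this gain. Whether it belongs to formyl alone stays open, since the compounds shown include neither acetyl nor methyl on this nitrogen, nor a plain hydrogen.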